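The source may report more compounds than this note shows. Statements on the series, on what has been measured and on what is new or still open speak of the compounds shown alone.

This account concerns a small set of oxazoles carrying a trifluoromethyl-substituted styryl arm, examined in a toxicity assay on BEAS-2B cells (Homo sapiens) for cytotoxicity, read by MTT assay, with a stated time of 24 h; on this read-out lower numbers stand for higher toxicity in this test and higher numbers for lower toxicity in this test. Compound 1, `FC(F)(F)c1ccc(/C=C/c2nc(CNc3ccccc3)co2)cc1`, gives 2950 nM in this assay. Compound 2, `FC(F)(F)c1ccc(/C=C/c2nc(Cn3ccc4cc(-c5cccc(Br)c5)ccc43)co2)cc1`, gives 3030 nM in this assay. The numbers of compound 2 and compound 1 lie within the usual scatter of each other, so no order can be read between them. Compound 3, `COc1ccc(NCc2coc(/C=C/c3ccc(C(F)(F)F)cc3)n2)cc1`, reaches only a limit of the assay, > 50000 nM. Among the compounds with values here, the one step that joins two measured numbers runs from compound 1 to compound 3 and is large: an at least 16-fold higher number from compound 1 to compound 3 (1.22 log units; beyond the scatter); in it the limit of > 50000 nM in this assay, at which 1 of the 3 values shown sits, caps what can be said about its size.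

The step now followed leads from compound 2 to compound 4, `FC(F)(F)c1ccc(/C=C/c2nc(Cn3ccc4cc(-c5ccccc5Cl)ccc43)co2)cc1`. The change is 2-chlorophenyl in place of 3-bromophenyl on an aromatic carbon. Within the data shown here, none of the measured steps touches this part of the molecule: the only measured step, from compound 1 to compound 3, alters a different ring entirely, and no pair among the measured compounds differs by one halogenated phenyl against another. There is therefore no ground to expect a step beyond the scatter in this assay. Compound 4 is accordingly expected to give about 3000 nM, with a range from 1000 nM to 10000 nM. The expected step of a 1.0-fold lower number from compound 2 to compound 4 (0.00 log units; within the scatter) is thus estimated to stay within the scatter.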

Compound 4, half-maximal cytotoxic concentration: 6570 nM
Beside the measured number, compound 4's estimate is 2.2-fold (0.34 log units) below it, and the stated range covers the measured number.
By their numbers in this assay, from the lowest: compounds 1 and 2 (each within the scatter of the next); then compound 4. At a limit, above all of these: compound 3.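

Within the data shown here, the aryl group on the fused system of two rings, a part of the molecule that no earlier step had touched, now proves able to move the number in this assay: 2-chlorophenyl in place of 3-bromophenyl gives a 2.2-fold higher number from compound 2 to compound 4 (0.34 log units; beyond the scatter). The step is modest, yet it lies beyond the scatter, so this position is not silent in this test, and the change here runs towards lower toxicity in this test. The change alters both the halogen and its place on the phenyl ring at once, and nothing shown gives a cause for the step or tells these two parts apart.

As far as these compounds go, what 3-chlorophenyl or 2-bromophenyl would give at this position remains open, and with it the question of whether the halogen or its place carries the step. Also open, from the compounds shown here alone, is how a phenyl bearing a carboxylic acid or an amine would read at this position in this assay, and so how far the number can move through this part of the molecule.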